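A few compounds are considered here, and "the series" means these few. Any claim that something is new, unique, unknown or untested is made for them only; others in the source may bear on it.

Working notes on the series. Three benzylpiperidine amides share a common core: compound 1 `COc1ccc(CN2CCC(CCNC(=O)/C=C/c3cc(C(C)(C)C)c(O)c(C(C)(C)C)c3)CC2)cc1`, compound 2 `Cc1ccccc1CN1CCC(CCNC(=O)/C=C/c2cc(C(C)(C)C)c(O)c(C(C)(C)C)c2)CC1` and compound 3 `Cc1ccc(CN2CCC(CCNC(=O)/C=C/c3cc(C(C)(C)C)c(O)c(C(C)(C)C)c3)CC2)cc1`. In an assay on isolated protein for inhibition of Amine oxidase [flavin-containing] B (Homo sapiens), read by fluorescence, with stated times of 15 min and 20 min (on this read-out higher numbers stand for weaker inhibition and lower numbers for stronger inhibition), compound 1 gives 6700 nM, compound 2 gives 7200 nM and compound 3 gives 8900 nM. Going by the values given here, compound 3 stands with the other two in a tight cluster: the steps of a 1.3-fold higher number from compound 1 to compound 3 (0.12 log units; within the scatter) and a 1.2-fold higher number from compound 2 to compound 3 (0.09 log units; within the scatter) are both within the scatter, as is a 1.1-fold higher number from compound 1 to compound 2 (0.03 log units; within the scatter), so no member of the trio separates from the others.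

Compound 4 `CC(C)(C)c1cc(/C=C/C(=O)NCCC2CCN(Cc3ccccc3F)CC2)cc(C(C)(C)C)c1O` is not yet measured. Relative to compound 3 it carries 2-fluorophenyl in place of 4-methylphenyl on a saturated chain carbon bound to an amine nitrogen in a ring. Among the compounds with values here, the steps that bear on this change are those that swap the group on the same saturated chain carbon: a 1.1-fold higher number from compound 1 to compound 2 (0.03 log units; within the scatter) exchanges a 4-substituted phenyl for a 2-substituted one and a 1.2-fold higher number from compound 2 to compound 3 (0.09 log units; within the scatter) reverses that pattern, both without leaving the scatter. Within the data shown here, no measured step therefore argues for movement in this assay in either direction. Compound 4 is estimated at 8000 nM, range 4000 nM to 16000 nM, meaning an expected step of a 1.1-fold lower number from compound 3 to compound 4 (0.05 log units; within the scatter), none beyond the scatter.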

Compound 4, half-maximal inhibitory concentration: 7400 nM
Compound 4: the middle estimate sits 1.1-fold (0.03 log units) above what was measured; the measured number falls inside the stated range.
By their numbers in this assay, from the lowest: compounds 1, 2, 4 and 3 (each within the scatter of the next).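

In this assay, the new group gives a 1.2-fold lower number from compound 3 to compound 4 (0.08 log units; within the scatter), while fluoro in place of methyl on an aromatic carbon gives a 1.0-fold higher number from compound 2 to compound 4 (0.01 log units; within the scatter) and 2-fluorophenyl in place of 4-methoxyphenyl gives a 1.1-fold higher number from compound 1 to compound 4 (0.04 log units; within the scatter), all within the scatter. Going by these compounds alone, a fluorine-bearing group now joins 4-methoxyphenyl, 2-methylphenyl and 4-methylphenyl on a saturated chain carbon bound to an amine nitrogen in a ring, and no member of the four separates from the others. No evidence is available on what lies behind these values.

Going by these compounds, all four compounds carry a substituted phenyl at this place, so it remains open whether a carboxylic acid, an amine or a longer chain there would move the number beyond the scatter. The shared core is constant throughout, so these steps say nothing about changes elsewhere in it.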